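Para-Methoxy on the Cinnamamide Arm: Expected Cytotoxicity

The source may report more compounds than this note shows. Statements on the series, on what has been measured and on what is new or still open speak of the compounds shown alone.

Measured so far, in a functional assay on BGC-823 cells (Homo sapiens) for cytotoxicity, read by MTT assay, with a stated time of 72 h; a higher number here means a weaker inhibitor, a lower number a stronger inhibitor:
Compound 1, `CN1[C@@H]2c3[nH]c4ccccc4c3C[C@H]1[C@H](C#N)N1[C@@H](CNC(=O)/C=C/c3cccc(C(F)(F)F)c3)c3[nH]c4ccccc4c3C[C@@H]21`, gives 910 nM.
Compound 2, `CN1[C@@H]2c3[nH]c4ccccc4c3C[C@H]1[C@H](C#N)N1[C@@H](CNC(=O)/C=C/c3ccccc3)c3[nH]c4ccccc4c3C[C@@H]21`, gives 4300 nM.

Compound 2 has the highest of the two numbers; its nearest neighbour is compound 1, which lies lower by a 4.7-fold higher number from compound 1 to compound 2 (0.67 log units; beyond the scatter) read in reverse, a gap beyond the scatter. Within the data shown here, the only step that exists so far is that one, a 4.7-fold higher number from compound 1 to compound 2 (0.67 log units; beyond the scatter), a modest step in which hydrogen replaced trifluoromethyl on an aromatic carbon of the phenyl at the end of the cinnamamide arm.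

Compound 3, `COc1ccc(/C=C/C(=O)NC[C@H]2c3[nH]c4ccccc4c3C[C@H]3[C@H]4c5[nH]c6ccccc6c5C[C@@H]([C@H](C#N)N23)N4C)cc1`, is not yet measured. It differs from compound 2 in one place: methoxy in place of hydrogen on an aromatic carbon. Among the measured compounds shown here, no measured step involves a methoxy group, and the one step available concerns a different group at a different place on the same ring, so it bears only loosely on this change. It shows that a substituent on that ring can move the number beyond the scatter, without telling the direction for methoxy. The step from compound 2 to compound 3 in this assay is therefore expected to be small, a 1.4-fold lower number from compound 2 to compound 3 (0.16 log units; within the scatter), likely within or only just beyond the scatter, leaning toward a lower number. Compound 3 is estimated at 3000 nM, within 1000 nM to 9000 nM.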

Compound 3, half-maximal inhibitory concentration: 5450 nM
Compound 3: middle estimate off by 1.8-fold (0.26 log units), on the low side, and the stated range covers the measured number.
By their numbers in this assay, from the lowest: compound 1; then compounds 2 and 3 (each within the scatter of the next).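

In this assay, adding methoxy to the phenyl ring of the cinnamamide arm, para to a large group, gives a 1.3-fold higher number from compound 2 to compound 3 (0.10 log units; within the scatter). Among these compounds, this position therefore carries a methoxy group with no readable change in the number, something the earlier pair could not show, since its only step involved trifluoromethyl. The second step, a 6.0-fold higher number from compound 1 to compound 3 (0.78 log units; beyond the scatter), shows that having a substituent on this ring is not enough to reach the level of compound 1, although that step changes both the group and its place on the ring at once, so neither can be credited alone; no measurement shown gives a reason for either step.

The compounds shown leave open whether methoxy would read differently on the ring carbon that holds trifluoromethyl in compound 1, and whether trifluoromethyl would keep its lower number on the carbon that holds methoxy in compound 3. They also leave open how an amine or a carboxylic acid on this ring would read, since methoxy and trifluoromethyl are the only substituents on it so far.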